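Pyrazole to Methoxypyrrolidine on the Amide Side Chain

The source may hold more compounds than are shown below. What is called first, only, known or untested is meant among the compounds shown, and "the series" means these compounds.

Measured compounds:
compound 1 `C[C@@H]1CN(c2sc(C(F)(F)F)nc2-c2nc3ccccc3[nH]2)CCN1C(=O)Cn1cccn1` 191 nM
compound 2 `Cc1nc(C)n(CC(=O)N2CCN(c3sc(C(F)(F)F)nc3-c3nc4ccc(C5CCOCC5)cc4[nH]3)C[C@H]2C)n1` 123 nM
compound 3 `C[C@@H]1CN(c2sc(C(F)(F)F)nc2-c2nc3ccc(CO)cc3[nH]2)CCN1C(=O)Cn1cnc2cccnc21` 92.4 nM

In a functional assay on Venous blood for antagonist activity at C-X-C chemokine receptor type 3 (Homo sapiens), read by flow cytometry, with a stated time of 30 min, in the presence of a further agent that is not named here (on this read-out higher numbers stand for weaker inhibition and lower numbers for stronger inhibition), compound 1 gives the highest of the three numbers. Its gap to compound 2 lies within the scatter, while compound 3 sits beyond the scatter on the lower side. Compound 4 `COC1CCN(CC(=O)N2CCN(c3sc(C(F)(F)F)nc3-c3nc4ccccc4[nH]3)C[C@H]2C)C1` keeps the shared core of compound 1 and differs only on the amide side chain: 3-methoxypyrrolidin-1-yl in place of 1H-pyrazol-1-yl on a saturated chain carbon bound to a carbonyl carbon. Within the data shown here, no measured pair shows this change, so nothing tells how large a step it brings. The estimate for compound 4 treats the step from compound 1 as a 1.0-fold higher number from compound 1 to compound 4 (0.02 log units; within the scatter), with no clear direction beyond the scatter. In this assay compound 4 is therefore expected to give about 200 nM, within a range of 80 nM to 500 nM.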

Compound 4, half-maximal inhibitory concentration: 3380 nM
The estimate for compound 4 lay 17-fold (1.23 log units) below the measured number, outside the stated range (above it).
By their numbers in this assay, from the lowest: compounds 3, 2 and 1 (each within the scatter of the next, the first and the last beyond it); then compound 4.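

In this assay, among these compounds, the amide side chain proves to be a sensitive position: on the shared core, 3-methoxypyrrolidin-1-yl in place of 1H-pyrazol-1-yl gives an 18-fold higher number from compound 1 to compound 4 (1.25 log units; beyond the scatter), a large loss of inhibition that the earlier compounds, which differ in more than one place, could not isolate. Both groups have the same counts of hydrogen-bond donors and acceptors and no net charge, so these counts do not separate them. Nothing available accounts for the size of this step. On these data alone, it remains open whether the methoxy group or the non-aromatic ring carries the loss; a plain pyrrolidin-1-yl group on the same chain carbon would separate the two.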